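Triazole series: aryl change from compound 3 to compound 4

The source may report more compounds than this note shows. Statements on the series, on what has been measured and on what is new or still open speak of the compounds shown alone.

Compound 3 `Oc1cc(C(F)(F)F)ccc1-c1nc(-c2ccccc2O)n(-c2ccc(Cl)cc2)n1` gives 96.1% in a functional assay on PC-12 cells (Rattus norvegicus) for cytotoxicity, read by MTT assay, with stated times of 2 h and 24 h, tested at 10 uM; a lower number here means a weaker effect, a higher number a stronger effect of the compound at the concentration tested. Among the three compounds measured it stands lowest: compound 1 `CCc1ccc(-n2nc(-c3ccc(C(F)(F)F)cc3O)nc2-c2ccccc2O)cc1` gives 107% and compound 2 `CC(C)c1ccc(-n2nc(-c3ccc(C(F)(F)F)cc3O)nc2-c2ccccc2O)cc1` gives 108% in this assay. The step of a number 10.9 percentage points lower from compound 1 to compound 3 (beyond the scatter) and the step of a number 11.9 percentage points lower from compound 2 to compound 3 (beyond the scatter) both lie beyond the scatter, while the step of a number 1 percentage points higher from compound 1 to compound 2 (within the scatter) does not. Compound 4 `Oc1cc(C(F)(F)F)ccc1-c1nc(-c2ccccc2O)n(-c2cccc(C(F)(F)F)c2)n1` differs from compound 3 in one place: 3-(trifluoromethyl)phenyl in place of 4-chlorophenyl on an aromatic nitrogen. The change alters the same aryl group that the measured steps altered, so the steps from compound 1 and compound 2 to compound 3 are the ones that bear on it, and both were modest. Going by the values given here, no measured step covers trifluoromethyl on this aryl group, and the measured steps give no direction for it. The step expected in this assay is therefore a number 3.9 percentage points higher from compound 3 to compound 4 (within the scatter), not beyond the scatter. Compound 4 is estimated at 100%, with a range from 85% to 115%.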

Compound 4, a percentage reported as activity, at one concentration (the size of the read-out at that concentration, not a potency): 99.9%
Compound 4: middle estimate off by 0.1 percentage points, on the high side; measured number inside the range.
By their numbers in this assay, from the lowest: compounds 3, 4, 1 and 2 (each within the scatter of the next, the first and the last beyond it).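

The step to 3-(trifluoromethyl)phenyl on the aromatic nitrogen is a number 3.8 percentage points higher from compound 3 to compound 4 (within the scatter) in this assay, and the steps from the two alkyl-bearing aryl groups are a number 8.1 percentage points lower from compound 2 to compound 4 (within the scatter) and a number 7.1 percentage points lower from compound 1 to compound 4 (within the scatter). Compound 4 therefore lies within the scatter of all three earlier compounds, although compound 3 is separated from compound 1 and compound 2 by steps beyond the scatter, so the trifluoromethyl aryl group does not fall clearly on either side of that gap. Nothing available accounts for these numbers at this position.

Open, on these data alone, is whether 4-(trifluoromethyl)phenyl reads like 3-(trifluoromethyl)phenyl in this assay. Also open, as far as these compounds go, is whether an aryl group carrying an amine or a carboxylic acid on this nitrogen would give a larger step than the modest ones seen so far.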